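The source may hold more compounds than are shown below. What is called first, only, known or untested is meant among the compounds shown, and "the series" means these compounds.

Measured in the series so far:
- compound 1 `CCCCN1CCN(C(=S)SC(=S)N(C)C)CC1` — 4100000 nM
- compound 2 `CN(C)C(=S)SC(=S)N1CCN(c2ncccn2)CC1` — limit only, > 5000000 nM
- compound 3 `CCCCSC(=S)N1CCN(C(=S)SC(=S)N(C)C)CC1` — limit only, > 5000000 nM

All three were run in an ADME assay on HeLa cells (Homo sapiens) for cytotoxicity, read by MTT assay, with a stated time of 24 h; a lower number here means a stronger inhibitor, a higher number a weaker inhibitor. Among the compounds with values here, compound 1 is the only member with a numeric read-out. Compound 2 is reported only as a limit of this assay. Compound 3 likewise is reported only as a limit, so its standing is an open-ended one, shared with compound 2 at the limit of > 5000000 nM in this assay, at which 2 of the 3 values shown sit.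

The steps recorded are small or unreadable: an at least 1.2-fold higher number from compound 1 to compound 2 (0.08 log units; that floor lies within the scatter); an at least 1.2-fold higher number from compound 1 to compound 3 (0.08 log units; that floor lies within the scatter); and a step that the two limits leave unreadable from compound 2 to compound 3. None of them shows a change beyond the scatter of this assay.

Compound 4 `CCCCNC(=S)N1CCN(C(=S)SC(=S)N(C)C)CC1` is not yet measured. It differs from compound 3 by butylamino in place of butylsulfanyl on a thiocarbonyl carbon. Within the data shown here, the only step that bears on this position is the one on the same ring nitrogen, an at least 1.2-fold higher number from compound 1 to compound 3 (0.08 log units; that floor lies within the scatter), and it gave no readable movement. No step beyond the scatter is therefore expected, a number no higher from compound 3 to compound 4 (the limit leaves the size open), and the estimated value for compound 4 in this assay is 5000000 nM, within a range of 2000000 nM to 10000000 nM, most likely again reported as a limit.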

Compound 4, half-maximal inhibitory concentration: 2840000 nM
Compound 4: middle estimate off by 1.8-fold (0.25 log units), on the high side; the range from low to high includes it.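

In this assay butylamino in place of butylsulfanyl on a thiocarbonyl carbon gives this position its first numeric read-out, where compound 3 holds only a limit. The change trades a hydrogen-bond acceptor for a hydrogen-bond donor at the same heavy-atom count, and the result is an at least 1.7-fold lower number from compound 3 to compound 4 (0.24 log units; that floor lies within the scatter) and likewise an at least 1.7-fold lower number from compound 2 to compound 4 (0.24 log units; that floor lies within the scatter), so neither floor separates these groups. Compared with the butyl group on the ring nitrogen, the record is a 1.4-fold lower number from compound 1 to compound 4 (0.16 log units; within the scatter), and the two floors rest on open-ended values: the limit of > 5000000 nM in this assay, at which 2 of the 4 values shown sit.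

On these data alone, whether any group on this thiocarbonyl carbon can give a step beyond the scatter remains open. As far as these compounds go, a longer chain, a carboxylic acid or a phenyl ring in place of butylamino would test this, and the true size of the step from compound 3 also remains unknown.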